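Halogen pattern on the aryl ketone in cytotoxicity

The source may report more compounds than this note shows. Statements on the series, on what has been measured and on what is new or still open speak of the compounds shown alone.

Measured compounds:
Compound 1 `COc1cc(-c2cc(/C=C/C(=O)c3ccc(Cl)c(Cl)c3)[nH]n2)cc(OC)c1OC` — 5%
Compound 2 `COc1ccc(C(=O)/C=C/c2cc(-c3cc(OC)c(OC)c(OC)c3)n[nH]2)cc1` — -31%

In a functional assay on NCI-H322M cells (Homo sapiens) for cytotoxicity, read by sulforhodamine B assay, with a stated time of 48 h, tested at 100 uM (on this read-out higher numbers stand for a weaker effect at the one concentration tested and lower numbers for a stronger effect), compound 2 gives -31%, the lower of the two measured values; compound 1 gives 5%. Going by the values given here, the single measured step, a number 36 percentage points lower from compound 1 to compound 2 (beyond the scatter), separates them, so compound 2 stands as the stronger of the pair on this read-out.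

Compound 3 `COc1cc(-c2cc(/C=C/C(=O)c3ccc(F)c(F)c3)[nH]n2)cc(OC)c1OC` has not yet been tested. It differs from compound 2 in one place: 3,4-difluorophenyl in place of 4-methoxyphenyl on a carbonyl carbon. The change undoes the substitution of the measured step and puts a pair of halogens back on the same ring positions, now fluorine instead of chlorine. The only step that bears on it is therefore a number 36 percentage points lower from compound 1 to compound 2 (beyond the scatter), and run in reverse it points to a rise in this assay, though whether fluorine behaves like chlorine here is not shown by any measured compound.

Compound 3 is expected to read close to the value of compound 1, and the step from compound 2 is estimated as a number 28 percentage points higher from compound 2 to compound 3 (beyond the scatter). The estimate for compound 3 is -3%, with a range from -33% to 27%.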

Compound 3, a percentage reported as activity, at one concentration (the size of the read-out at that concentration, not a potency): 3%
Compound 3: middle estimate off by 6 percentage points, on the low side, and the stated range covers the measured number.
By their numbers in this assay, from the lowest: compound 2; then compounds 3 and 1 (each within the scatter of the next).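

In this assay, 3,4-difluorophenyl in place of 4-methoxyphenyl on the carbonyl carbon gives a number 34 percentage points higher from compound 2 to compound 3 (beyond the scatter), so a large gap from compound 2 now appears with a second halogen pair and not only with the dichlorinated ring of compound 1. The direct halogen exchange, 3,4-difluorophenyl in place of 3,4-dichlorophenyl, gives a number 2 percentage points lower from compound 1 to compound 3 (within the scatter), and on this read-out the fluorine and chlorine pairs therefore cannot be told apart. Among these three compounds, the clear division at this position lies between the 4-methoxyphenyl group of compound 2 and the two dihalogenated phenyl groups, while the identity of the halogen makes no difference beyond the scatter.

No measurement among the data shown accounts for this division between the methoxy-bearing ring and the halogen-bearing rings. From the compounds shown here alone, it also remains open whether the stronger effect of compound 2 is particular to the 4-methoxyphenyl group or would also be seen with an amine, a hydroxyl or a carboxylic acid on the phenyl ring at this carbonyl carbon.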